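A few compounds are considered here, and "the series" means these few. Any claim that something is new, unique, unknown or untested is made for them only; others in the source may bear on it.

Of the compounds shown here, three sharing one core have been tested in a toxicity assay on THP-1 cells (Homo sapiens) for inhibition; on this read-out lower numbers stand for higher toxicity in this test and higher numbers for lower toxicity in this test. Compound 1, `COc1ccc(-c2cnc(NC(=O)C3CCCCC3)n2C)cc1`, carries a cyclohexyl on the carbonyl carbon. In this assay compound 1 gives > 100000 nM, which is a limit of the assay and not a number. Compound 2, `Cc1ccccc1C(=O)Nc1ncc(-c2ccccc2)n1C`, was tested in the same way. In this assay compound 2 gives > 100000 nM, again a limit of the assay. Compound 3, `COc1ccc(-c2cnc(NC(=O)c3cccc(Br)c3)n2C)cc1`, carries 3-bromophenyl in place of cyclohexyl on the carbonyl carbon. In this assay compound 3 gives > 100000 nM, once more a limit rather than a number. The step that the two limits leave unreadable from compound 1 to compound 3 therefore cannot be read in size. Compound 3 thus stands exactly where every measured compound stands: the limit of > 100000 nM in this assay, at which 3 of the 3 values shown sit.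

Compound 4, `Cn1c(-c2ccccc2)cnc1NC(=O)c1cccc(Br)c1`, differs from compound 3 by hydrogen in place of methoxy on an aromatic carbon. Among the compounds with values here, no measured step bears directly on this change; the single measured step, a step that the two limits leave unreadable from compound 1 to compound 3, concerns another place and is itself unreadable. Compound 2, which also carries phenyl, sits at that same limit. Nothing therefore points to toxicity appearing, and the expected step that the limit leaves unreadable from compound 3 to compound 4 is no step beyond the scatter. Compound 4 is expected to give 150000 nM, with a range from 50000 nM to 500000 nM, most probably reported once more as a limit.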

Compound 4, half-maximal cytotoxic concentration: > 50000 nM
Compound 4: no number, only a limit; the forecaster's own chance of this, stated with the estimate: 85%; the middle value does not contradict the limit.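

In this assay compound 4 gives > 50000 nM, which is a limit of the assay and not a number. The steps to compound 4 from compound 3 and from compound 2 cannot be read in size. The compounds shown leave open what cytotoxic concentration any of the four has in this assay, as all four values are limits.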